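The compounds below may be only part of what the source reports. "The series", "measured", "known", "first", "only" and "open" are said of these compounds alone.

Measured in a functional assay on RAW264.7 cells (Mus musculus) for inhibition; on this read-out higher numbers stand for weaker inhibition and lower numbers for stronger inhibition:
- compound 1 `CCOC(=O)C1=C(S(=O)(=O)Nc2ccc(Cl)cc2F)CCCC1`: 1700 nM
- compound 2 `COC(=O)C1=CCCCC1S(=O)(=O)Nc1ccc(F)cc1F`: 57 nM

Compound 2 holds the lower of the two numbers in this assay, and its gap to compound 1 lies beyond the scatter. These two compounds differ in more than one place, so their gap gives no size for a single change.

Compound 3 `CC(C)COC(=O)C1=CCCCC1S(=O)(=O)Nc1ccc(F)cc1F` is not yet measured. It departs from compound 2 by isopropyl in place of hydrogen on a saturated chain carbon bound to an oxygen next to a carbonyl group, or methoxycarbonyl to isobutoxycarbonyl. Among the measured compounds shown here, no measured pair isolates this change, so the expectation is tentative: a modest move towards a higher number, near the edge of the scatter.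

The expected change is a 1.6-fold higher number from compound 2 to compound 3 (0.20 log units; within the scatter).

For compound 3 the estimated value is 90 nM, with an expected range of 25 nM to 350 nM.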

Compound 3, half-maximal inhibitory concentration: 49 nM
Compound 3: middle estimate off by 1.8-fold (0.26 log units), on the high side, within the range that was stated.
By their numbers in this assay, from the lowest: compounds 3 and 2 (each within the scatter of the next); then compound 1.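

In this assay, among the compounds shown here, isopropyl in place of hydrogen on a saturated chain carbon bound to an oxygen next to a carbonyl group gives a 1.2-fold lower number from compound 2 to compound 3 (0.07 log units; within the scatter) and so provides the first single change that can be read. At this position, going from methoxycarbonyl to isobutoxycarbonyl leaves the two numbers within the scatter, so the added isopropyl carries no measurable penalty or gain in this pair. No available measurement accounts for this result.

Going by these compounds, whether a carboxylic acid or a longer chain in place of the isobutoxycarbonyl would also keep the number within the scatter remains open. The gap to compound 1 also remains unassigned, as compound 1 differs from compound 2 in more than one place.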